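Shortening the alkyl chain and solubility at neutral pH

The source may report more compounds than this note shows. Statements on the series, on what has been measured and on what is new or still open speak of the compounds shown alone.

Compound 1 `CCCCCCCCN(C)/N=N/c1ccc(C(=O)O)cc1`: 171000 nM
Compound 2 `CCCCCN(C)/N=N/c1ccc(C(=O)O)cc1`: 4280000 nM
Compound 3 `CCC(C)CN(C)/N=N/c1ccc(C(=O)O)cc1`: 16200000 nM

In a physicochemical assay for solubility, in phosphate buffer, at pH 7.4 (a lower number here means a less soluble compound, a higher number a more soluble compound), compound 2 stands second highest of the three, below compound 3 and well above compound 1. Compound 4 `CCCCN(C)/N=N/c1ccc(C(=O)O)cc1` differs from compound 2 by hydrogen in place of methyl on a saturated chain carbon, four bonds along the chain from an amine nitrogen. For the measured compounds named here, two measured steps bear on this change. The first, a 25-fold higher number from compound 1 to compound 2 (1.40 log units; beyond the scatter), is the same kind of shortening, only a longer one. The second, a 3.8-fold higher number from compound 2 to compound 3 (0.58 log units; beyond the scatter), removes one carbon but also adds branching. Taking one carbon from the chain is therefore expected to give a modest rise in this assay, not a large one. The expected step is a 2.8-fold higher number from compound 2 to compound 4 (0.45 log units; beyond the scatter). For compound 4 the estimate is 12000000 nM, within a range from 5000000 nM to 30000000 nM.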

Compound 4, solubility: 15500000 nM
Estimate against measurement, compound 4: 1.3-fold (0.11 log units) below, within the range that was stated.
By their numbers in this assay, from the lowest: compound 1; then compound 2; then compounds 4 and 3 (each within the scatter of the next).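

In this assay, hydrogen in place of methyl at this place, four bonds along the chain from an amine nitrogen, gives a 3.6-fold higher number from compound 2 to compound 4 (0.56 log units; beyond the scatter), so losing this single carbon already counts beyond the scatter. The longer shortening gives a 91-fold higher number from compound 1 to compound 4 (1.96 log units; beyond the scatter). The added methyl of compound 3 makes no readable difference, with a 1.0-fold lower number from compound 3 to compound 4 (0.02 log units; within the scatter).

On these data alone, what a propyl chain, or an amide in place of the carboxylic acid, would give stays open. Nothing shown here gives a reason for these steps.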